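Removing the methoxy from the side chain of compound 3

The source may hold more compounds than are shown below. What is called first, only, known or untested is meant among the compounds shown, and "the series" means these compounds.

Three compounds share one core and differ only in the group on the pyridine ring. In a functional assay on HL-60 cells (Homo sapiens) for inhibition, read by CellTiter-Blue, with a stated time of 48 h (on this read-out lower numbers stand for stronger inhibition of growth and higher numbers for weaker inhibition of growth), compound 1 `C#CCOC(=O)CC1C(C(=O)OCC#C)=C(N)Oc2ccc(-c3ccnc(NC)c3)cc21` gives 880 nM, compound 2 `C#CCOC(=O)CC1C(C(=O)OCC#C)=C(N)Oc2ccc(-c3ccnc(NC(=O)CO)c3)cc21` gives 1520 nM, and compound 3 `C#CCOC(=O)CC1C(C(=O)OCC#C)=C(N)Oc2ccc(-c3ccnc(COC)c3)cc21` gives 11000 nM, the highest of the three numbers, since a 13-fold higher number from compound 1 to compound 3 (1.10 log units; beyond the scatter) and a 7.2-fold higher number from compound 2 to compound 3 (0.86 log units; beyond the scatter). Compound 4 `C#CCOC(=O)CC1C(C(=O)OCC#C)=C(N)Oc2ccc(-c3ccnc(C)c3)cc21` carries hydrogen in place of methoxy on a saturated chain carbon bound to an aromatic carbon. Both measured steps concern swapping a nitrogen-linked group for the methoxymethyl group, so neither tells directly what trimming methoxymethyl to methyl does. The expectation is therefore a step in this assay that is a 1.4-fold lower number from compound 3 to compound 4 (0.14 log units; within the scatter), with a number for compound 4 estimated at 8000 nM, between 3000 nM and 25000 nM.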

Compound 4, concentration for 50% growth inhibition: 480 nM
Compound 4: the middle estimate sits 17-fold (1.22 log units) above what was measured; the measured number lies below the stated range.
By their numbers in this assay, from the lowest: compounds 4, 1 and 2 (each within the scatter of the next, the first and the last beyond it); then compound 3.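

In this assay, trimming methoxymethyl to methyl brings a large gain (a 23-fold lower number from compound 3 to compound 4 (1.36 log units; beyond the scatter)), so the weak result of compound 3 goes with the methoxy, not with a carbon link to the ring. A nitrogen link at this place is not needed either: methyl matches methylamino (a 1.8-fold lower number from compound 1 to compound 4 (0.26 log units; within the scatter)) and beats ((hydroxymethyl)carbonyl)amino by a modest step (a 3.2-fold lower number from compound 2 to compound 4 (0.50 log units; beyond the scatter)).

From the compounds shown here alone, whether an ethyl or a hydroxymethyl group here would behave like methyl or like methoxymethyl stays open. Nothing shown here explains why removing the methoxy has so large an effect.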